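The source may hold more compounds than are shown below. What is called first, only, known or untested is meant among the compounds shown, and "the series" means these compounds.

Measured so far:
compound 1 `O=C(Nc1nc2ccc(Cl)cc2s1)c1cn(-c2ccccc2)nc1-c1ccc(F)cc1`, 3870 nM in a functional assay on A549 cells (Homo sapiens) for cytotoxicity, read by MTT assay, with a stated time of 72 h; on this read-out lower numbers stand for stronger inhibition and higher numbers for weaker inhibition
compound 2 `O=C(Nc1nc2ccc(F)cc2s1)c1cn(-c2ccccc2)nc1-c1ccc(Cl)cc1`, 8860 nM in this assay

Compound 2 holds the highest of the two numbers; its nearest neighbour, compound 1, differs from it in two places, and the gap between them lies beyond the scatter. Compound 3 `O=C(Nc1nc2ccc(Cl)cc2s1)c1cn(-c2ccccc2)nc1-c1ccc(Cl)cc1` follows from compound 2 by the change (chloro in place of fluoro on an aromatic carbon), chloro in place of fluoro on an aromatic carbon. Within the data shown here, no single-change step between measured compounds sizes this move. For compound 3 the estimate is 4500 nM, range 2000 nM to 10000 nM. The expected step is a 2.0-fold lower number from compound 2 to compound 3 (0.29 log units; within the scatter), a modest move toward lower numbers, because compound 1 with chloro on the shared core gives 3870 nM.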

Compound 3, half-maximal inhibitory concentration: 4360 nM
Beside the measured number, compound 3's estimate is 1.0-fold (0.01 log units) above it, and the stated range covers the measured number.
By their numbers in this assay, from the lowest: compounds 1 and 3 (each within the scatter of the next); then compound 2.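

In this assay, among these compounds, replacing 6-fluoro-1,3-benzothiazol-2-yl with 6-chloro-1,3-benzothiazol-2-yl gives a 2.0-fold lower number from compound 2 to compound 3 (0.31 log units; beyond the scatter) and so provides the first sized single-change step at this position, modest but beyond the scatter. The same kind of exchange made elsewhere on the molecule gives a 1.1-fold higher number from compound 1 to compound 3 (0.05 log units; within the scatter) and stays within the scatter, so the two sites do not respond alike in this pair of steps. Nothing available accounts for that difference.

Each site rests on a single step. On these data alone, whether methoxy, trifluoromethyl or an amine on the same aromatic carbon would shift the number further remains open.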